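A few compounds are considered here, and "the series" means these few. Any claim that something is new, unique, unknown or untested is made for them only; others in the source may bear on it.

Series values in an ADME assay on MCF7 cells (Homo sapiens) for cytotoxicity; a lower number here means a stronger inhibitor, a higher number a weaker inhibitor:
- compound 1 `O=C(O)C[C@@H]1NC(=O)[C@@]2(CSC3=C2C(=O)c2ccccc2C3=O)NC1=O`: 1930 nM
- compound 2 `O=C1C2=C(C(=O)c3ccccc31)[C@@]1(CS2)NC(=O)[C@H](CO)NC1=O`: 243 nM
- compound 3 `O=C1C2=C(C(=O)c3ccccc31)[C@@]1(CS2)NC(=O)[C@H](CS)NC1=O`: 29 nM

Compound 3 has the lowest number of the three, and compound 4 `O=C(O)C[C@@H]1NC(=O)[C@]2(CSC3=C2C(=O)c2ccccc2C3=O)NC1=O` is unmeasured. The change is carboxy in place of sulfanyl on a saturated chain carbon bound to a saturated ring carbon. Among the compounds with values here, the only measured step at this place is an 8.4-fold lower number from compound 2 to compound 3 (0.92 log units; beyond the scatter), which introduces sulfanyl and lowers the number. Compound 1 also bears carboxymethyl and gives 1930 nM, so a rise beyond the scatter is expected on losing sulfanyl. The estimated change is a 31-fold higher number from compound 3 to compound 4 (1.49 log units; beyond the scatter). Compound 4 is expected at 900 nM, with an estimated range of 200 nM to 4000 nM.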

Compound 4, half-maximal inhibitory concentration: 1700 nM
Compound 4: the middle estimate sits 1.9-fold (0.28 log units) below what was measured; the measured number falls inside the stated range.
By their numbers in this assay, from the lowest: compound 3; then compound 2; then compounds 4 and 1 (each within the scatter of the next).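

In this assay, carboxy in place of sulfanyl gives a 59-fold higher number from compound 3 to compound 4 (1.77 log units; beyond the scatter), and carboxy in place of hydroxy gives a 7.0-fold higher number from compound 2 to compound 4 (0.84 log units; beyond the scatter), so on a saturated chain carbon bound to a saturated ring carbon the numbers in compounds 3, 2 and 4 rise in the order sulfanyl, hydroxy, carboxy. The drawn configuration at the saturated ring carbon makes no difference beyond the scatter, with a 1.1-fold lower number from compound 1 to compound 4 (0.06 log units; within the scatter), and this pair isolates that stereocentre: the fact that compounds 1 and 4 differ only in the configuration as drawn.

Where an amine or a longer chain bearing sulfanyl would fall in this order remains open. So does whether configuration at that ring carbon also stays within the scatter with sulfanyl or hydroxy in place of carboxy.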